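The compounds below may be only part of what the source reports. "The series", "measured", "known", "first", "only" and "open" are said of these compounds alone.

Measured so far:
- compound 1, `Cc1nn(-c2ncnc3nc[nH]c23)c2c1C(c1ccc(OC(C)C)cc1)CC(=O)N2`: 2700 nM
- compound 2, `Cc1nn(-c2ncnc3nc[nH]c23)c2c1C(OCCc1ccccc1)CC(=O)N2`: 40 nM

Among the measured compounds shown here, compound 2 gives the lowest of the two numbers obtained in a functional assay on HEK293 cells for agonist activity at G-protein coupled receptor 39 (Homo sapiens), read by scintillation proximity assay and inositol phosphate accumulation, with a stated time of 75 min; on this read-out higher numbers stand for an effect only at larger amounts of compound and lower numbers for an effect already at smaller amounts; its nearest neighbour is compound 1, and the only measured step, a 68-fold lower number from compound 1 to compound 2 (1.83 log units; beyond the scatter), is a large one beyond the scatter, in favour of the phenethyloxy group over the directly attached aromatic ring.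

Compound 3, `Cc1nn(-c2ncnc3nc[nH]c23)c2c1C(c1ccc(F)cc1Cl)CC(=O)N2`, carries the change (2-chloro-4-fluorophenyl in place of phenethyloxy on a saturated ring carbon). This puts a directly attached aromatic ring back onto the saturated ring carbon, which is the kind of substituent compound 1 carries, and compound 1 gave the far higher number. For the measured compounds named here, the only step that bears on this, a 68-fold lower number from compound 1 to compound 2 (1.83 log units; beyond the scatter), therefore argues that compound 3 should move back upward in this assay, though the halogen pattern of compound 3 differs from the 4-isopropoxyphenyl of compound 1, so the full reversal need not be reached. For compound 3 in this assay a step of a 20-fold higher number from compound 2 to compound 3 (1.30 log units; beyond the scatter) is expected, and the estimate for compound 3 is 800 nM with a range from 150 nM to 4000 nM.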

Compound 3, half-maximal effective concentration: 280 nM
The estimate for compound 3 lay 2.9-fold (0.46 log units) above the measured number; the range from low to high includes it.
By their numbers in this assay, from the lowest: compound 2; then compound 3; then compound 1.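

In this assay a directly attached aromatic ring on the saturated ring carbon does not by itself fix the number at the high end, since exchanging 4-isopropoxyphenyl for 2-chloro-4-fluorophenyl gives a 9.6-fold lower number from compound 1 to compound 3 (0.98 log units; beyond the scatter) and so shows that the substituents on that ring count at this position. The phenethyloxy group still holds the lowest number of the three, and exchanging it for 2-chloro-4-fluorophenyl gives a 7.0-fold higher number from compound 2 to compound 3 (0.85 log units; beyond the scatter) which is a much smaller penalty than the one seen earlier with 4-isopropoxyphenyl, so the aryl compounds are not all equally far from compound 2. Nothing at hand explains either step or says what lies behind the order of the three compounds.

The compounds shown do not separate the share of the chlorine from that of the fluorine, nor tell whether the absence of the isopropoxy group alone accounts for the lower number of compound 3. They also leave open whether the ether oxygen and the length of the chain in compound 2 are both needed, as a benzyloxy group, a longer chain or an amine in place of that oxygen would show.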